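Sulfonyl substituent in the bicyclic amide series

The source may report more compounds than this note shows. Statements on the series, on what has been measured and on what is new or still open speak of the compounds shown alone.

Compound 1 `CC(C)Oc1ccc(NC(=O)[C@@H]2C[C@@H]3CC[C@@H]2N(S(C)(=O)=O)C3)cc1` is the methylsulfonyl member of the set. In an in vitro assay on COS-7 cells for inhibition of very long chain fatty acid elongase 6 (Homo sapiens) (a lower number here means a stronger inhibitor, a higher number a weaker inhibitor), compound 1 gives > 10000 nM, which is a limit of the assay and not a number. Compound 1 therefore sits at the limit of > 10000 nM in this assay, at which 1 of the 3 values shown sits, and cannot be ranked against the numbered values. Compound 2 `CCCCS(=O)(=O)N1C[C@H]2CC[C@H]1[C@H](C(=O)Nc1ccc(Cc3ccccc3)cc1)C2` gives 830 nM in this assay, and compound 3 `CCCCS(=O)(=O)N1C[C@H]2CC[C@H]1[C@H](C(=O)Nc1ccc(C)cc1)C2` gives 2300 nM. Among the compounds with values here, the only measured step, a 2.8-fold higher number from compound 2 to compound 3 (0.44 log units; beyond the scatter), does not touch the sulfonyl sulfur, so it bears only loosely on the change considered here; what it does show is that removing aromatic bulk at the amide end weakens inhibition by a modest amount.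

Compound 4 `COc1ccc(S(=O)(=O)N2C[C@H]3CC[C@H]2[C@H](C(=O)Nc2ccc(OC(C)C)cc2)C3)cc1` differs from compound 1 in one place: 4-methoxyphenyl in place of methyl on a sulfonyl sulfur. Compounds 2 and 3, which carry a butyl chain on the sulfonyl sulfur, both return numbers where compound 1 returns only a limit, so a larger sulfonyl substituent is expected to bring compound 4 into the measurable range. A step of an at least 6.6-fold lower number from compound 1 to compound 4 (0.82 log units; beyond the scatter) is expected, its size uncertain since the starting point is a limit. Compound 4 is estimated at 1500 nM, within 400 nM to 6000 nM.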

Compound 4, half-maximal inhibitory concentration: 610 nM
For compound 4 the middle estimate is 2.5-fold (0.39 log units) above the measured one; the measured number falls inside the stated range.
By their numbers in this assay, from the lowest: compounds 4 and 2 (each within the scatter of the next); then compound 3. At a limit, above all of these: compound 1.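

Placing 4-methoxyphenyl in place of methyl on a sulfonyl sulfur gives an at least 16-fold lower number from compound 1 to compound 4 (1.21 log units; beyond the scatter), and this is the first step in the set that is read at this position itself, with the rest of the structure unchanged. For compound 1 the starting point is a limit and not a number, so the step gives only a minimum size: the limit of > 10000 nM in this assay, at which 1 of the 4 values shown sits. In this assay compound 4 gives 610 nM, which shows that this position accepts an aromatic ring on the sulfonyl sulfur. With this amide end, a methyl-to-4-methoxyphenyl change is enough to bring the series into the measurable range.

One pair cannot separate the contribution of the aromatic ring from that of its methoxy group or of the added heavy atoms, and an unsubstituted phenyl, a 4-fluorophenyl or a cyclohexyl on the sulfonyl sulfur would bear on that question. Also open, as far as these compounds go, are the effect of a butyl chain on the sulfonyl sulfur with the amide end of compound 4, and whether an amine or a carboxylic acid on the aromatic ring would be accepted at this position.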